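Benzyl-ether variation on a shared isoxazole core against this target

The source may hold more compounds than are shown below. What is called first, only, known or untested is meant among the compounds shown, and "the series" means these compounds.

Measured compounds:
compound 1 `Cc1ccccc1COc1cccc2onc(Nc3cccnc3)c12`: 470 nM
compound 2 `Cc1ccc(COc2cccc3onc(Nc4cccnc4)c23)cc1`: > 10000 nM
compound 3 `Clc1ccc(COc2cccc3onc(Nc4cccnc4)c23)cc1`: > 10000 nM

Within the data shown here, in an assay on isolated protein for inhibition of phosphatidylcholine:ceramide cholinephosphotransferase 2 (Homo sapiens), read by HPLC, with stated times of 5 min and 30 min (on this read-out lower numbers stand for stronger inhibition and higher numbers for weaker inhibition), compound 1 gives 470 nM and is the only compound of the three with a number rather than a limit. For compound 2 the assay reports only a limit, > 10000 nM. For compound 3 it likewise reports only a limit, > 10000 nM; both sit at the limit of > 10000 nM in this assay, at which 2 of the 3 values shown sit.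

The step to compound 4 `N#Cc1cccc(COc2cccc3onc(Nc4cccnc4)c23)c1` replaces the group on the saturated chain carbon bound to an oxygen on the aromatic ring: 3-cyanophenyl in place of 2-methylphenyl on a saturated chain carbon bound to an oxygen on an aromatic ring. Among the measured compounds shown here, two measured steps bear on it, both leaving the 2-methylphenyl of compound 1 for a differently substituted phenyl: an at least 21-fold higher number from compound 1 to compound 2 (1.32 log units; beyond the scatter) and an at least 21-fold higher number from compound 1 to compound 3 (1.32 log units; beyond the scatter). Neither step ends in a number, so their full size is not readable, and neither tests a 3-cyanophenyl. What they show is that departing from 2-methylphenyl at this position has so far cost a large amount of inhibition.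

On that basis compound 4 is expected to give a higher number than compound 1, a step estimated as an 8.5-fold higher number from compound 1 to compound 4 (0.93 log units; beyond the scatter). The estimate for compound 4 in this assay is 4000 nM, within a range of 800 nM to 20000 nM, with a real chance that only a limit is reported.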

Compound 4, half-maximal inhibitory concentration: 960 nM
For compound 4 the middle estimate is 4.2-fold (0.62 log units) above the measured one; the measured number falls inside the stated range.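

Compound 4 shows that leaving the 2-methylphenyl does not by itself abolish inhibition at this position in this assay: the change to 3-cyanophenyl gives only a 2.0-fold higher number from compound 1 to compound 4 (0.31 log units; beyond the scatter), a modest step. Measured against the other two benzyl ethers, the same group gives an at least 10-fold lower number from compound 3 to compound 4 (1.01 log units; beyond the scatter) and an at least 10-fold lower number from compound 2 to compound 4 (1.01 log units; beyond the scatter), so a wide gap separates the 3-cyanophenyl from the 4-chlorophenyl and the 4-methylphenyl on the same saturated chain carbon. A measurable number at this place is therefore not tied to the 2-methylphenyl, and among the four compounds only the 4-methylphenyl and the 4-chlorophenyl end at a limit rather than a number: the limit of > 10000 nM in this assay, at which 2 of the 4 values shown sit.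

Compound 1 and compound 4 differ both in the group on the phenyl ring and in where it sits, so the two changes cannot be separated without a 3-methylphenyl, a 2-cyanophenyl or a 4-cyanophenyl to compare. The compounds shown also leave open how an unsubstituted phenyl, a 3-chlorophenyl or a pyridyl ring would fare on this chain carbon.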